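Cytotoxicity notes: chloro in place of methoxy

The source may report more compounds than this note shows. Statements on the series, on what has been measured and on what is new or still open speak of the compounds shown alone.

Three compounds carry numbers in a functional assay on MDA-MB-231 cells (Homo sapiens) for cytotoxicity, read by MTT assay; a higher number here means a weaker inhibitor, a lower number a stronger inhibitor. Compound 1 `COc1cccc(/C=C2\CCC/C(=C\c3ccccc3[N+](=O)[O-])C2=O)c1` gives 14.3 ug/mL. Compound 2 `CCCOc1c(Br)cc(/C=C2\CCC/C(=C\c3ccccc3[N+](=O)[O-])C2=O)cc1OC` gives 1.99 ug/mL in this assay. Compound 3 `COc1ccc(/C=C2\CCC/C(=C\c3cccc([N+](=O)[O-])c3)C2=O)cc1` gives 44.7 ug/mL in this assay, the highest of the three numbers; compound 1 sits nearest to it, with a number lower by an amount beyond the scatter, and compound 2 furthest, lower still and well beyond the scatter. Compound 4 `O=C1/C(=C/c2cccc(Cl)c2)CCC/C1=C\c1cccc([N+](=O)[O-])c1` has not been measured. It differs from compound 3 in one place: 3-chlorophenyl in place of 4-methoxyphenyl on a double-bonded chain carbon bound to a double-bonded ring carbon. Among the measured compounds shown here, no pair of measured compounds differs in a single place, so no measured step shows how this change acts; the only hint is that the one compound carrying a halogen, compound 2, shows the lowest number, though it differs from compound 3 in more than one place. The step from compound 3 to compound 4 is expected to be modest, toward a lower number, and may fall within the scatter: a 2.2-fold lower number from compound 3 to compound 4 (0.35 log units; beyond the scatter) is the estimate. Compound 4 is expected to give about 20 ug/mL in this assay, with a range from 6 ug/mL to 60 ug/mL.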

Compound 4, half-maximal inhibitory concentration: 5.01 ug/mL
The estimate for compound 4 lay 4.0-fold (0.60 log units) above the measured number; the whole stated range lies above it.
By their numbers in this assay, from the lowest: compound 2; then compound 4; then compound 1; then compound 3.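

In this assay, among the compounds shown here, 3-chlorophenyl in place of 4-methoxyphenyl on a double-bonded chain carbon bound to a double-bonded ring carbon gives an 8.9-fold lower number from compound 3 to compound 4 (0.95 log units; beyond the scatter), the first single-place step, and it shows that the number responds to this position while the rest of the molecule stays fixed. The change swaps the whole group, so the step cannot divide its size between the change of substituent and the change in where that substituent stands. Nothing available bears on why the number falls.

Compound 1 and compound 2 differ from compound 3 and compound 4 in more than one place, so their steps cannot be read. Open too, from the compounds shown here alone, is whether an amine or a carboxylic acid in place of the chlorine would keep the lower number.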